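The compounds below may be only part of what the source reports. "The series", "measured", "known", "first", "only" and "open" are said of these compounds alone.

Measured so far in a functional assay on MDA-MB-231 cells (Homo sapiens) for inhibition, read by MTT assay, with a stated time of 48 h; a higher number here means a weaker inhibitor of growth, a lower number a stronger inhibitor of growth:
- compound 1 `S=C(Nc1ccccc1)Nc1ccc2ncnc(Nc3cccc(Br)c3)c2c1`: 10000 nM
- compound 2 `Oc1ccc(NC(=S)Nc2ccc3ncnc(Nc4cccc(Br)c4)c3c2)cc1`: 17300 nM
- compound 3 `FC(F)(F)c1cc(NC(=S)Nc2ccc3ncnc(Nc4cccc(Br)c4)c3c2)ccc1Cl`: 1100 nM

Compound 3 has the lowest number of the three, and its steps to both others lie beyond the scatter. Compound 4 `S=C(Nc1cc(Cl)cc(Cl)c1)Nc1ccc2ncnc(Nc3cccc(Br)c3)c2c1` differs from it by one change, 3,5-dichlorophenyl in place of 4-chloro-3-(trifluoromethyl)phenyl on an amide-type nitrogen. Among the compounds with values here, two measured steps bear on this group: a 9.1-fold lower number from compound 1 to compound 3 (0.96 log units; beyond the scatter) and a 16-fold lower number from compound 2 to compound 3 (1.20 log units; beyond the scatter). Both bring in the group that now leaves. Within the data shown here, no measured compound carries the entering group, but it keeps chlorine on the ring, so only a small change in this assay is expected, with the number, if anything, somewhat higher. The expected step is a 1.6-fold higher number from compound 3 to compound 4 (0.21 log units; within the scatter). For compound 4 the estimate is 1800 nM, with an expected range of 600 nM to 5500 nM.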

Compound 4, concentration for 50% growth inhibition: 3000 nM
For compound 4 the middle estimate is 1.7-fold (0.22 log units) below the measured one; the range from low to high includes it.
By their numbers in this assay, from the lowest: compound 3; then compound 4; then compounds 1 and 2 (each within the scatter of the next).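

In this assay, 3,5-dichlorophenyl on this amide-type nitrogen keeps part of the gain over phenyl, with a 3.3-fold lower number from compound 1 to compound 4 (0.52 log units; beyond the scatter), and over 4-hydroxyphenyl, with a 5.8-fold lower number from compound 2 to compound 4 (0.76 log units; beyond the scatter). It does not match 4-chloro-3-(trifluoromethyl)phenyl, however, with a 2.7-fold higher number from compound 3 to compound 4 (0.44 log units; beyond the scatter), so chlorine on the ring does not by itself set the number at this position. Nothing available explains these differences.

Whether a trifluoromethyl group alone or a single chlorine would account for the difference between compound 3 and compound 4 remains open. So does the effect of an amine or a carboxylic acid on this ring.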